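Methyl on the core ring: effect on growth inhibition

This account rests on a few compounds, and the source may have more. Where it says the series, first, only, none or still open, it means among the compounds named here.

Measured in a functional assay on HeLa cells (Homo sapiens) for inhibition, read by sulforhodamine B assay, with a stated time of 48 h; on this read-out lower numbers stand for stronger inhibition of growth and higher numbers for weaker inhibition of growth:
compound 1 `c1ccc(-c2nc3ncccn3c2CN2CCCC2)cc1` gives 70 nM
compound 2 `CC(C)(C)c1nc2ncccn2c1CN1CCCCC1` gives 30 nM
compound 3 `Cc1ccn2c(CN3CCCCC3)c(C(C)(C)C)nc2n1` gives 450 nM

Going by the values given here, the one counted change in the set is methyl in place of hydrogen on an aromatic carbon, which produced a 15-fold higher number from compound 2 to compound 3 (1.18 log units; beyond the scatter). Compound 4 `Cc1ccn2c(CN3CCCC3)c(-c3ccccc3)nc2n1` is not yet measured; it differs from compound 1 by methyl in place of hydrogen on an aromatic carbon, the same change at the same place. The difference between the core of compound 1 and the core of compound 2 is not broken down here. Compound 4 is expected to give 700 nM in this assay. The expected range for compound 4 runs from 250 nM to 2500 nM. The step expected from the parent is a 10-fold higher number from compound 1 to compound 4 (1.00 log units; beyond the scatter), set somewhat smaller than the earlier one because a 15-fold higher number from compound 2 to compound 3 (1.18 log units; beyond the scatter) is a single example on a different core.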

Compound 4, concentration for 50% growth inhibition: 180 nM
Beside the measured number, compound 4's estimate is 3.9-fold (0.59 log units) above it, outside the stated range (below it).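

In this assay, methyl in place of hydrogen on an aromatic carbon again gives weaker growth inhibition, with a 2.6-fold higher number from compound 1 to compound 4 (0.41 log units; beyond the scatter), so the direction of the step is shared by both cores. The size of the step does not carry over from one core to the other: the same change on two cores in this assay, a 15-fold higher number (1.18 log units; beyond the scatter) from compound 2 to compound 3 and a 2.6-fold higher number (0.41 log units; beyond the scatter) from compound 1 to compound 4, 5.8-fold (0.77 log units) apart, beyond the scatter of two such steps. Going by these compounds alone, the two pairs do not show which difference between the cores sets the size, and with only two examples they give no rule for a further core.

From the compounds shown here alone, it remains open whether an ethyl or methoxy group, or an amine, at the same place would follow the direction seen with methyl. Going by these compounds, how any such group would compare across the two cores also remains open.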